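Swapping the aryl group on the carbonyl of a quinoline chalcone

The source may hold more compounds than are shown below. What is called first, only, known or untested is meant among the compounds shown, and "the series" means these compounds.

Measured compounds:
compound 1, `COc1ccc(-c2cc3ccccc3nc2/C=C/C(=O)c2ccc(F)cc2)cc1`: 5450 nM
compound 2, `COc1ccc(-c2cc3ccccc3nc2/C=C/C(=O)c2ccc(OC)c(OC)c2)cc1`: 6030 nM
compound 3, `COc1ccc(-c2cc3ccccc3nc2/C=C/C(=O)c2ccc(N)cc2)cc1`: 6920 nM

These three compounds share one core and differ only in the ring attached to the carbonyl carbon. In a functional assay on MCF7 cells (Homo sapiens) for antiproliferative activity, read by XTT assay, with a stated time of 72 h (on this read-out lower numbers stand for stronger inhibition and higher numbers for weaker inhibition), compound 1 gives 5450 nM, compound 2 gives 6030 nM and compound 3 gives 6920 nM. Compound 3 sits alongside the other two: the step of a 1.3-fold higher number from compound 1 to compound 3 (0.10 log units; within the scatter) and the step of a 1.1-fold higher number from compound 2 to compound 3 (0.06 log units; within the scatter) are both within the scatter, as is a 1.1-fold higher number from compound 1 to compound 2 (0.04 log units; within the scatter). Compound 4, `COc1ccc(-c2cc3ccccc3nc2/C=C/C(=O)c2cccs2)cc1`, carries the change (thiophen-2-yl in place of 4-aminophenyl on a carbonyl carbon). The three steps already seen all exchange the ring on this same carbonyl carbon, and none of them moved the number beyond the scatter, so the expectation is again no step beyond the scatter in this assay for compound 4. The expected step is a 1.1-fold lower number from compound 3 to compound 4 (0.03 log units; within the scatter). Compound 4 is therefore estimated at 6500 nM, in a range from 2500 nM to 17000 nM.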

Compound 4, half-maximal inhibitory concentration: 1030 nM
Estimate against measurement, compound 4: 6.3-fold (0.80 log units) above; measured number outside the range, below it.
By their numbers in this assay, from the lowest: compound 4; then compounds 1, 2 and 3 (each within the scatter of the next).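

In this assay, the ring on the carbonyl carbon proves able to shift the number, which the exchanges among the three six-membered rings did not show: thiophen-2-yl brings steps beyond the scatter against all of them (a 6.7-fold lower number from compound 3 to compound 4 (0.83 log units; beyond the scatter); a 5.9-fold lower number from compound 2 to compound 4 (0.77 log units; beyond the scatter); a 5.3-fold lower number from compound 1 to compound 4 (0.72 log units; beyond the scatter)). Compound 4 therefore stands apart from compounds 1, 2 and 3, and it is the only one here with a five-membered aromatic ring and the only one with sulfur. No measurement shown gives a reason for this difference.

The compounds shown leave open whether the lower number belongs to thiophen-2-yl alone or would also appear with furan-2-yl or thiophen-3-yl. They also do not tell whether a methyl group or a chlorine on the thiophene ring would keep it.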